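Working notes: stepping from compound 2 to compound 4

The source may hold more compounds than are shown below. What is called first, only, known or untested is meant among the compounds shown, and "the series" means these compounds.

Measured in a functional assay on MCF7 cells (Homo sapiens) for antiproliferative activity, read by MTT assay, with a stated time of 72 h; a lower number here means a stronger inhibitor, a higher number a weaker inhibitor:
- compound 1 `CCCSc1nc(N/N=C(\C)c2ccccc2O)c2nnn(Cc3ccc(Cl)cc3)c2n1`: 42600 nM
- compound 2 `CCCSc1nc(N/N=C/c2ccc(C)cc2)c2nnn(Cc3ccccc3)c2n1`: > 64000 nM (a limit, not a number)
- compound 3 `CCCSc1nc(N/N=C/c2cccnc2)c2nnn(Cc3ccccc3)c2n1`: 58700 nM

Compound 2 has no numerical value in this assay, only the limit > 64000 nM. This is the limit of > 64000 nM in this assay, at which 1 of the 3 values shown sits. The step therefore starts from a limit and not from a fixed point.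

Compound 4 `CCCSc1nc(N/N=C(\C)c2ccc(O)cc2)c2nnn(Cc3ccccc3)c2n1` has not yet been measured. Its difference from compound 2 is a group of 10 heavy atoms (8 carbon, 1 nitrogen, 1 oxygen; one six-membered aromatic ring of carbon only) in place of a group of 9 heavy atoms (8 carbon, 1 nitrogen; one six-membered aromatic ring of carbon only), on a nitrogen on an aromatic ring.

For the measured compounds named here, one measured step bears on this change, since it also alters the group carried on the carbon with a double bond to nitrogen. That step is an at least 1.0-fold lower number from compound 2 to compound 3 (0.03 log units; that floor lies within the scatter). It gives no sign of a large effect from replacing that group. Compound 1 at 42600 nM and compound 3 at 58700 nM lie within the scatter of each other, so the numerical values shown occupy a narrow band.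

No step beyond the scatter is expected in this assay, and no direction can be assigned. The estimated step is an at least 1.2-fold lower number from compound 2 to compound 4 (0.10 log units; that floor lies within the scatter). For compound 4 the expected value is 50000 nM, with an estimated range from 25000 nM to 90000 nM.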

Compound 4, half-maximal inhibitory concentration: 21600 nM
Estimate against measurement, compound 4: 2.3-fold (0.36 log units) above, outside the stated range (below it).
By their numbers in this assay, from the lowest: compounds 4, 1 and 3 (each within the scatter of the next, the first and the last beyond it). At a limit, above all of these: compound 2.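

In this assay, for the compounds shown here, the group of 10 heavy atoms, with 1 hydrogen-bond donor, on a nitrogen on an aromatic ring gives the first steps that lie beyond the scatter: an at least 2.9-fold lower number from compound 2 to compound 4 (0.47 log units; beyond the scatter) and a 2.7-fold lower number from compound 3 to compound 4 (0.43 log units; beyond the scatter). The earlier step, an at least 1.0-fold lower number from compound 2 to compound 3 (0.03 log units; that floor lies within the scatter), gave only a floor within the scatter, whereas these results show that a change to this group can move the number measurably, though the sizes remain modest. Going by these compounds, the step from compound 2 starts from a limit and not from a number, and its true size stays open: the limit of > 64000 nM in this assay, at which 1 of the 4 values shown sits.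

The compounds shown do not separate the contribution of the oxygen in the entering group from that of its extra carbon, as compound 4 differs from compound 2 and from compound 3 in the whole group. On these data alone, it also remains open how this group would read with an amine or a carboxylic acid in place of that oxygen, or with a longer chain in place of the extra carbon.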